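A few compounds are considered here, and "the series" means these few. Any claim that something is new, unique, unknown or untested is made for them only; others in the source may bear on it.

Measured compounds in a functional assay on MCF7 cells (Homo sapiens) for inhibition, read by MTT assay, with a stated time of 72 h; a lower number here means a stronger inhibitor, a higher number a weaker inhibitor:
- compound 1 `O=C(Nc1ccc(Oc2ccnc3[nH]ccc23)cc1)c1cn(-c2ccc(Cl)cc2)c2ccccc2c1=O` gives 1590 nM
- compound 2 `O=C(Nc1ccc(Oc2ccnc3[nH]ccc23)cc1)c1cn(-c2ccc(C(F)(F)F)cc2Cl)c2ccccc2c1=O` gives 3570 nM

For the measured compounds named here, compound 2 has the highest number of the two, and the only other compound, compound 1, lies a 2.2-fold higher number from compound 1 to compound 2 (0.35 log units; beyond the scatter) away. Compound 3 `O=C(Nc1ccc(Oc2ccnc3[nH]ccc23)c(F)c1)c1cn(-c2ccc(C(F)(F)F)cc2Cl)c2ccccc2c1=O` keeps the whole of compound 2 and differs only by fluoro in place of hydrogen on an aromatic carbon, on the six-membered aromatic ring of carbon only that carries the amide nitrogen. Going by the values given here, the one measured step, a 2.2-fold higher number from compound 1 to compound 2 (0.35 log units; beyond the scatter), concerns a change on the aryl group attached to the aromatic nitrogen, not this ring, so no measured step speaks directly to the change from compound 2 to compound 3. A single fluorine entering an aromatic ring is a small change, and without a matching step the expectation is a move that stays within the usual scatter, in no fixed direction. The estimated step from compound 2 to compound 3 is therefore a 1.0-fold lower number from compound 2 to compound 3 (0.01 log units; within the scatter). Compound 3 is expected to give about 3500 nM in this assay, with a likely range from 1400 nM to 8500 nM.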

Compound 3, half-maximal inhibitory concentration: 1120 nM
The estimate for compound 3 lay 3.1-fold (0.49 log units) above the measured number, and the stated range ends above it.
By their numbers in this assay, from the lowest: compounds 3 and 1 (each within the scatter of the next); then compound 2.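

In this assay, the ring that carries the amide nitrogen proves sensitive to a single added atom: fluoro in place of hydrogen on an aromatic carbon gives a 3.2-fold lower number from compound 2 to compound 3 (0.50 log units; beyond the scatter) and so moves the number by more than the usual scatter. For the compounds shown here, this is the first measured change on that ring, as the earlier step lay on the aryl group on the aromatic nitrogen, and here the number goes down rather than up. No measurement at hand bears on the reason for this step.

On these data alone, how a chloro, a methoxy or an amine at this same place would compare with fluoro remains open. Also open, as far as these compounds go, is whether the fluoro step would carry over to compound 1, with its 4-chlorophenyl group, since fluoro on this ring appears here only with the 2-chloro-4-(trifluoromethyl)phenyl group.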